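Benzylidene hydantoin acetamides: growth inhibition notes

The compounds below may be only part of what the source reports. "The series", "measured", "known", "first", "only" and "open" are said of these compounds alone.

Measured compounds:
- compound 1, `O=C(CN1C(=O)N/C(=C/c2ccc(Cl)cc2)C1=O)Nc1cccc(C(F)(F)F)c1`: 22900 nM
- compound 2, `O=C(CN1C(=O)N/C(=C\C=C\c2ccccc2)C1=O)Nc1ccc(Cl)cc1`: < 100000 nM

In a functional assay on MDA-MB-231 cells (Homo sapiens) for inhibition, read by sulforhodamine B assay, with a stated time of 48 h (a lower number here means a stronger inhibitor of growth, a higher number a weaker inhibitor of growth), compound 1 gives 22900 nM. For compound 2 this assay returns only a limit, < 100000 nM, and no number; this is the situation described by the limit of < 100000 nM in this assay, at which 1 of the 2 values shown sits. Within the data shown here, compound 2 therefore stands at an unresolved position on the scale, and no measured step between it and compound 1 is available.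

Compound 3, `O=C(CN1C(=O)N/C(=C\c2ccc(Cl)cc2)C1=O)Nc1ccc(Cl)cc1`, is not yet measured. It differs from compound 2 by 4-chlorophenyl in place of 2-phenylethenyl on a double-bonded chain carbon bound to a double-bonded ring carbon, while the amide side is the same in both. Compared with compound 1, compound 3 carries the same 4-chlorophenyl on the double-bonded chain carbon and differs only in the anilide, so compound 1 is the closest anchor with an actual number.

With compound 2 at a limit, the expected step that the limit leaves unreadable from compound 2 to compound 3 cannot be sized from a measured pair. Compound 3 is expected to land near the value of compound 1, estimated at 25000 nM (range 8000 nM to 80000 nM), with a real chance that this assay again reports only a limit.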

Compound 3, concentration for total growth inhibition: 42700 nM
For compound 3 the middle estimate is 1.7-fold (0.23 log units) below the measured one, and the stated range covers the measured number.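

No step from compound 2 to compound 3 can be read in this assay, because compound 2 stands only at a limit: the limit of < 100000 nM in this assay, at which 1 of the 3 values shown sits.

The compounds shown leave open whether 4-chlorophenyl in place of 2-phenylethenyl, on a double-bonded chain carbon bound to a double-bonded ring carbon, strengthens growth inhibition, weakens it or leaves it unchanged.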